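The source may report more compounds than this note shows. Statements on the series, on what has been measured and on what is new or still open speak of the compounds shown alone.

Compound 1 `CN1CCN(CC(=O)Nc2ccc(-c3nc4cc(C(F)(F)F)ccc4n3C)cc2)CC1` — 44000 nM
Compound 2 `COc1ccc(-c2nc3cc(C(F)(F)F)ccc3[nH]2)c(OC)c1` — > 100000 nM
Compound 3 `CC(=O)Nc1ccc(-c2nc3ccccc3[nH]2)cc1` — > 100000 nM

Three compounds sharing the core of compound 1 have been examined in an ADME assay on MDBK cells (Bos taurus) for cytotoxicity, read by MTT assay, with a stated time of 96 h; a lower number here means that less compound is tolerated, a higher number that more compound is tolerated. Compound 1 is the only one of the three that returns an actual number: in this assay compound 1 gives 44000 nM. For compound 2 the assay reports only a limit, > 100000 nM. Compound 3 likewise returns a limit, > 100000 nM. Within the data shown here, compound 1 therefore stands alone as the one measured value, with the other two resting at the limit of > 100000 nM in this assay, at which 2 of the 3 values shown sit.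

Compound 4 `CCC(=O)Nc1ccc(-c2nc3cc(C(F)(F)F)ccc3n2C)cc1` has not yet been tested. It differs from compound 1 in a single place: methyl in place of 4-methylpiperazin-1-yl on a saturated chain carbon bound to a carbonyl carbon. Among the measured compounds shown here, with no pair of measured compounds that differs in one place, no measured step can anchor the change. Since two of the three compounds, compound 2 and compound 3, sit at the limit, compound 4 is expected to move toward better tolerance, a step of a 1.8-fold higher number from compound 1 to compound 4 (0.26 log units; within the scatter), though a step within the scatter cannot be excluded. Compound 4 is thus estimated to give 80000 nM in this assay, with a range from 30000 nM to 200000 nM, and a real chance that only a limit is reported.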

Compound 4, half-maximal cytotoxic concentration: > 100000 nM
Compound 4: only a limit was reported; the forecaster's own chance of this, stated with the estimate: 45%; at least 1.2-fold (0.09 log units) between middle value and limit.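

Compound 4 returns only a limit in this assay, > 100000 nM. Methyl in place of 4-methylpiperazin-1-yl on a saturated chain carbon bound to a carbonyl carbon gives an at least 2.2-fold higher number from compound 1 to compound 4 (0.35 log units; beyond the scatter), the first single-place step in this set, and it lies beyond the scatter. Among these compounds, compound 1 thus remains the only compound with an actual number, while the others share one limit: the limit of > 100000 nM in this assay, at which 3 of the 4 values shown sit.

On these data alone, how large the step really is stays open, as does whether the whole 4-methylpiperazin-1-yl group matters or only its outer amine nitrogen. Also open, as far as these compounds go, is whether a dimethylamino group, a morpholin-4-yl ring or a carboxylic acid in the same place would give a measurable number or also reach the limit.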